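The compounds below may be only part of what the source reports. "The series", "measured", "known", "first", "only" and "open" are said of these compounds alone.

Compound 1, `COc1cc(-n2ncnc2-c2cccc([N+](=O)[O-])c2)cc(OC)c1OC`: > 10000 nM
Compound 2, `COc1cc(-n2ncnc2-c2cccc(F)c2)cc(OC)c1OC`: > 10000 nM
Compound 3, `CCOc1cccc(-c2ncnn2-c2cc(OC)c(OC)c(OC)c2)c1`: > 10000 nM

In a functional assay on MCF7 cells (Homo sapiens) for antiproliferative activity, read by MTT assay, with a stated time of 72 h (a higher number here means a weaker inhibitor, a lower number a stronger inhibitor), compound 1 gives > 10000 nM, a limit of the assay rather than a number. Compound 2 likewise gives > 10000 nM in this assay, again only a limit. Compound 3 also returns a limit, > 10000 nM. Compound 2 therefore stands at the limit, as do the two other values shown (the limit of > 10000 nM in this assay, at which 3 of the 3 values shown sit). Among the measured compounds the steps are a step that the two limits leave unreadable from compound 1 to compound 2, a step that the two limits leave unreadable from compound 1 to compound 3 and a step that the two limits leave unreadable from compound 2 to compound 3, each of them unreadable in size because both ends sit at the limit. Compound 4, `COc1cc(-n2ncnc2-c2ccc(Cl)c(Cl)c2)cc(OC)c1OC`, differs from compound 2 by 3,4-dichlorophenyl in place of 3-fluorophenyl on an aromatic carbon. With no readable step among the measured compounds, it is expected that compound 4 will also remain at or near the limit, so the expected step is a number no higher from compound 2 to compound 4 (the limit leaves the size open). The estimate for compound 4 in this assay is 10000 nM, within 3000 nM to 30000 nM.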

Compound 4, half-maximal inhibitory concentration: > 10000 nM
Compound 4 was reported as a limit; the forecaster's own chance of this, stated with the estimate: 75%; the middle value sits exactly at the limit.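

Compound 2 and compound 4 both sit at a limit, so no size can be read for the step between them: the limit of > 10000 nM in this assay, at which 4 of the 4 values shown sit.

The compounds shown leave open whether any of these changes on the aromatic ring alters the activity at all.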